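Working notes: cytotoxicity in a carbonyl series

The source may report more compounds than this note shows. Statements on the series, on what has been measured and on what is new or still open speak of the compounds shown alone.

compound 1 `Cc1ccc(C(=O)c2ccn(-c3ccc4c(c3)B(O)OC4)c2)cc1`: > 10 ug/mL
compound 2 `O=C(c1ccc(O)cc1)c1ccn(-c2ccc3c(c2)B(O)OC3)c1`: > 10 ug/mL

In an ADME assay on L929 cells (Mus musculus) for cytotoxicity, read by resazurin assay, with a stated time of 72 h (on this read-out lower numbers stand for stronger inhibition and higher numbers for weaker inhibition), compound 2 stands at a limit only, with no number resolved. Both values shown sit at that limit (the limit of > 10 ug/mL in this assay, at which 2 of the 2 values shown sit). The change to compound 3 `O=C(CCc1ccccc1)c1ccn(-c2ccc3c(c2)B(O)OC3)c1` is phenethyl in place of 4-hydroxyphenyl on a carbonyl carbon. Within the data shown here, the only measured step, a step that the two limits leave unreadable from compound 1 to compound 2, is unreadable between two limits, so no size or direction can be taken from it. Compound 3 is therefore expected to stay near the limit, with a step that the limit leaves unreadable from compound 2 to compound 3 as the estimated step. The estimate for compound 3 in this assay is 15 ug/mL, with a range from 5 ug/mL to 50 ug/mL.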

Compound 3, half-maximal inhibitory concentration: > 10 ug/mL
Compound 3: a limit, no number; the forecaster's own chance of this, stated with the estimate: 75%; the middle value is on the limit's open side.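

No new step can be read from compound 1 or compound 2 to compound 3, as all three values are limits: the limit of > 10 ug/mL in this assay, at which 3 of the 3 values shown sit.

On these data alone, whether any of these group changes shifts the read-out in this assay stays open.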